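The compounds below may be only part of what the source reports. "The series", "measured", "known", "first", "only" and "open" are said of these compounds alone.

Measured in an ADME assay on BJ cells (Homo sapiens) for cytotoxicity, with a stated time of 72 h; a lower number here means that less compound is needed, a higher number that more compound is needed for the effect:
- Compound 1 `COc1cccc(-c2nc3c(c(C)nn3-c3ccccc3)c(-c3ccccc3O)c2C#N)c1`: > 23000 nM (a limit)
- Compound 2 `Cc1ccc(-c2nc3c(c(C)nn3-c3ccccc3)c(-c3ccccc3O)c2C#N)cc1`: 22200 nM
- Compound 3 `Cc1cccc(-c2nc3c(c(C)nn3-c3ccccc3)c(-c3ccccc3O)c2C#N)c1`: > 20000 nM (a limit)

Compound 3 has no number, only a limit, > 20000 nM. Compound 4 `Cc1nn(-c2ccccc2)c2nc(-c3ccc4ccccc4c3)c(C#N)c(-c3ccccc3O)c12` carries naphthalen-2-yl in place of 3-methylphenyl (naphthalen-2-yl in place of 3-methylphenyl on an aromatic carbon). Among the compounds with values here, no measured step makes this exact swap, but all three alter the group on that aromatic carbon. Only one has a readable size: an at least 1.0-fold lower number from compound 1 to compound 2 (0.01 log units; that floor lies within the scatter). Going by these compounds, the other two stay open: a step that the two limits leave unreadable from compound 1 to compound 3 and a step that the limit leaves unreadable from compound 2 to compound 3. With that small step and with compound 2 at 22200 nM, no step beyond the scatter is expected in this assay, in either direction. The expected change is a number no higher from compound 3 to compound 4 (the limit leaves the size open). For compound 4 the estimate is 20000 nM, with an expected range from 9000 nM to 40000 nM.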

Compound 4, half-maximal effective concentration: > 20000 nM
Compound 4 gave a limit, no number (the forecaster's own chance of this, stated with the estimate: 50%); the middle value sits exactly at the limit.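

In this assay compound 4 gave only a limit, > 20000 nM. Within the data shown here, no step linking it to compound 1, compound 2 or compound 3 can be read. The compounds shown leave open how naphthalen-2-yl compares with 3-methylphenyl on that aromatic carbon.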